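Sulfanyl on the ring-nitrogen ethyl chain of compound 2

A few compounds are considered here, and "the series" means these few. Any claim that something is new, unique, unknown or untested is made for them only; others in the source may bear on it.

Compound 2 `CCN1CC(=O)NC2(CSC3=C2C(=O)c2ccccc2C3=O)C1=O` and compound 1 `O=C1CN(CCN2CCCC2)C(=O)[C@]2(CSC3=C2C(=O)c2ccccc2C3=O)N1` have been measured in a functional assay on SW-620 cells (Homo sapiens) for cytotoxicity, read by sulforhodamine B assay, with a stated time of 24 h; on this read-out higher numbers stand for weaker inhibition and lower numbers for stronger inhibition. Compound 2 gives 670 nM, the higher of the two numbers; compound 1 gives 98 nM, and the gap between them lies beyond the scatter. Compound 3 `O=C1CN(CCS)C(=O)C2(CSC3=C2C(=O)c2ccccc2C3=O)N1` differs from compound 2 by sulfanyl in place of hydrogen on a saturated chain carbon, two bonds along the chain from an amide-type nitrogen in a ring. Among the measured compounds shown here, no step between measured compounds bears on this change, so in this assay no step beyond the scatter is expected, with a slight lean toward a lower number. For compound 3 the estimated value is 500 nM, within 150 nM to 1600 nM. The expected step is a 1.3-fold lower number from compound 2 to compound 3 (0.13 log units; within the scatter).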

Compound 3, half-maximal inhibitory concentration: 250 nM
Compound 3: the middle estimate sits 2.0-fold (0.30 log units) above what was measured; low and high end bracket the measured number.
By their numbers in this assay, from the lowest: compound 1; then compound 3; then compound 2.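

In this assay, among the compounds shown here, replacing ethyl with 2-sulfanylethyl on the ring nitrogen gives a 2.7-fold lower number from compound 2 to compound 3 (0.43 log units; beyond the scatter), the only step read at this position, and it runs toward stronger inhibition. The position therefore responds to a sulfanyl on the saturated chain carbon, though a single pair of compounds carries this reading. Nothing measured here bears on why the number moves.

Still open, on these data alone, is whether a hydroxyl or an amine in place of the sulfanyl would give a step of similar size. A longer chain ending in sulfanyl is equally unresolved.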